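The compounds below may be only part of what the source reports. "The series", "measured", "known", "first", "only" and "open" are said of these compounds alone.

Three compounds of this series carry numbers in a functional assay for inhibition, with Homo sapiens as the target; a lower number here means a stronger inhibitor, a higher number a weaker inhibitor. Compound 1 `Cc1cccc(Nc2nccc(-c3cccs3)n2)c1` gives 300 nM in this assay. Compound 2 `Oc1ccc(Nc2nccc(-c3cccnc3)n2)cc1` gives 5100 nM in this assay. Compound 3 `CC1CCN(C(=O)COc2ccc(Nc3nccc(-c4ccncc4)n3)cc2)CC1` gives 300 nM in this assay, level with compound 1 at the digits shown and, together with it, the lowest of the three numbers; compound 2 stands furthest from it, with a number beyond the scatter. Within the data shown here, no two of the measured compounds differ in a single place, so no step between them is counted.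

Compound 4 `CCN(CC)CCCOc1ccc(Nc2nccc(-c3ccncc3)n2)cc1` is not yet measured. It differs from compound 3 at one place: 2-(diethylamino)ethyl in place of (4-methylpiperidin-1-yl)carbonyl on a saturated chain carbon bound to an oxygen on an aromatic ring. The chain that enters and the group that leaves each bring one hydrogen-bond acceptor and no donor, and both sit on the same saturated chain carbon bound to an oxygen on an aromatic ring. Among the measured compounds shown here, nothing among the measured compounds shows what this exchange does.

The step is expected to stay within the scatter, with no direction favoured: a 1.2-fold higher number from compound 3 to compound 4 (0.07 log units; within the scatter). For compound 4 the expected value in this assay is 350 nM, with a range from 120 nM to 1000 nM.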

Compound 4, half-maximal inhibitory concentration: 1300 nM
Compound 4: the middle estimate sits 3.7-fold (0.57 log units) below what was measured; the measured number lies above the stated range.
By their numbers in this assay, from the lowest: compounds 1 and 3 (each within the scatter of the next); then compound 4; then compound 2.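

In this assay, this position on the oxygen-bearing side chain proves sensitive to the exchange: 3-(diethylamino)propyl in place of ((4-methylpiperidin-1-yl)carbonyl)methyl gives a 4.3-fold higher number from compound 3 to compound 4 (0.64 log units; beyond the scatter). The leaving and entering groups have equal counts of hydrogen-bond donors and acceptors, so matching counts do not keep the number level here. The ring and the double bond outside aromatic rings leave together, however, so this single step cannot assign the shift to either feature.

A (diethylcarbamoyl)methyl group or a 3-(4-methylpiperidin-1-yl)propyl group would separate the contribution of the carbonyl from that of the ring. No measurement shown accounts for the size of this step.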